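This account rests on a few compounds, and the source may have more. Where it says the series, first, only, none or still open, it means among the compounds named here.

Measured so far:
compound 1 `COc1cc(/C=C/C(=O)c2cccc(-n3cc(-c4ccc(Cl)cc4)[nH]c3=O)c2)cc(OC)c1OC` gives 16100 nM
compound 2 `O=C(/C=C/c1cccc(O)c1)c1cccc(-n2cc(-c3ccc(Cl)cc3)[nH]c2=O)c1` gives 1920 nM

In a functional assay on SNB-19 cells (Homo sapiens) for inhibition (a higher number here means a weaker inhibitor of growth, a lower number a stronger inhibitor of growth), compound 1 stands at the highest of the two numbers; compound 2 gives a lower number, and that gap lies beyond the scatter. Compound 3 `COc1cc(/C=C/C(=O)c2cccc(-n3cc(-c4ccccc4)[nH]c3=O)c2)cc(OC)c1OC` is not yet measured. It differs from compound 1 by hydrogen in place of chloro on an aromatic carbon. Going by the values given here, no measured pair shows this change, so a small shift is expected, if any: the step from compound 1 to compound 3 is estimated at a 1.4-fold higher number from compound 1 to compound 3 (0.14 log units; within the scatter), within the scatter or slightly weaker. Compound 3 is thus expected at 22000 nM, in the range 7000 nM to 70000 nM.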

Compound 3, concentration for 50% growth inhibition: 2350 nM
Compound 3: the middle estimate sits 9.4-fold (0.97 log units) above what was measured, outside the stated range (below it).
By their numbers in this assay, from the lowest: compounds 2 and 3 (each within the scatter of the next); then compound 1.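

In this assay, replacing the 4-chlorophenyl group with phenyl gives a 6.9-fold lower number from compound 1 to compound 3 (0.84 log units; beyond the scatter), so the chloro at this place, para to a large group, is not a neutral passenger in compound 1. Its removal alone moves the number beyond the scatter, and the direction favours the compound without the halogen. Nothing available explains why this single atom matters so much. Still open, as far as these compounds go, is whether a fluoro, a methyl or an amine at the same place would match hydrogen or chloro. Also open, from the compounds shown here alone, is whether the same change would act alike on compound 2.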